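From Trifluoromethyl to Methoxy in a Cytotoxicity Series

The source may hold more compounds than are shown below. What is called first, only, known or untested is meant among the compounds shown, and "the series" means these compounds.

Three related compounds have been measured in a functional assay on LOX IMVI cells (Homo sapiens) for cytotoxicity, read by MTT assay, with a stated time of 24 h; on this read-out higher numbers stand for weaker inhibition and lower numbers for stronger inhibition. Compound 1 `COc1cc(-c2nc(-c3ccccc3)[nH]c2-c2ccnc(NCCCNS(=O)(=O)c3ccc(C(F)(F)F)cc3)n2)ccc1F` gives 75200 nM. Compound 2 `COc1cc(-c2nc(-c3ccccc3)[nH]c2-c2ccnc(NCCCNS(=O)(=O)c3ccc(Cl)cc3)n2)ccc1Cl` gives 60900 nM. Compound 3 `COc1cc(-c2nc(-c3ccccc3)[nH]c2-c2ccnc(NCCCNS(=O)(=O)c3ccc(C(F)(F)F)cc3)n2)ccc1Cl` gives 1780 nM, the lowest number of the three and so the strongest inhibition.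

Compound 4 `COc1ccc(S(=O)(=O)NCCCNc2nccc(-c3[nH]c(-c4ccccc4)nc3-c3ccc(Cl)c(OC)c3)n2)cc1` differs from compound 3 in one group, with methoxy in place of trifluoromethyl on an aromatic carbon, para to a large group (methoxy in place of trifluoromethyl on an aromatic carbon).

Among the compounds with values here, two measured steps bear on this change. The closer one is a 34-fold lower number from compound 2 to compound 3 (1.53 log units; beyond the scatter), where trifluoromethyl takes the place of chloro at the very spot that changes now. The other is a 42-fold lower number from compound 1 to compound 3 (1.63 log units; beyond the scatter), where chloro replaces fluoro at a different spot, and it shows that a single swap can move the number a long way in this small set.

Within the data shown here, no measured compound carries 4-methoxyphenyl, so the size of the next step is uncertain. Among the measured compounds shown here, a higher number is still expected, given that the only other group measured at this spot, in compound 2, goes with 60900 nM. The expected step, again beyond the scatter, is an 8.4-fold higher number from compound 3 to compound 4 (0.93 log units; beyond the scatter). For compound 4 the estimated value is 15000 nM, with a likely range from 3000 nM to 70000 nM.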

Compound 4, half-maximal inhibitory concentration: 1800 nM
The estimate for compound 4 lay 8.3-fold (0.92 log units) above the measured number; the measured number lies below the stated range.
By their numbers in this assay, from the lowest: compounds 3 and 4 (each within the scatter of the next); then compounds 2 and 1 (each within the scatter of the next).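

In this assay, replacing trifluoromethyl with methoxy gives a 1.0-fold higher number from compound 3 to compound 4 (0.00 log units; within the scatter), so the two groups cannot be told apart here, even though the swap turns a 4-(trifluoromethyl)phenyl into a 4-methoxyphenyl and adds a hydrogen-bond acceptor that trifluoromethyl lacks. Within the data shown here, the spot itself is still sensitive, since methoxy in place of chloro gives a 34-fold lower number from compound 2 to compound 4 (1.53 log units; beyond the scatter), so chloro is now the one group of the three that goes with the much higher number, and the earlier contrast between chloro and trifluoromethyl did not show whether trifluoromethyl was special or chloro was the exception. No measurement shown here explains why methoxy and trifluoromethyl match while chloro stands apart.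

Among these compounds, with only three groups compared at this spot, and all of them on the same shared core, it remains open what an amine or a carboxylic acid would give there. Going by these compounds, it is also open whether methoxy would still match trifluoromethyl with fluoro in place of chloro at the other changed spot, as in compound 1, where the number is far higher.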